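Phenyl in place of cyclopropyl on a ring nitrogen

The source may hold more compounds than are shown below. What is called first, only, known or untested is meant among the compounds shown, and "the series" means these compounds.

Of the compounds shown here, three have been measured in an ADME assay on BaF3 cells (Mus musculus) for inhibition, read by CellTiter-Glo, with a stated time of 72 h; on this read-out higher numbers stand for weaker inhibition of growth and lower numbers for stronger inhibition of growth. Compound 1 `Cc1cc(Nc2ncc3c(n2)N(C)C(=O)N(c2cc(NC(=O)c4ccc(CN5CCC(N(C)C)C5)c(C(F)(F)F)c4)ccc2C)C3)n(C)n1` gives 509 nM, compound 2 `Cc1ccc(Nc2ncc3c(n2)N(C)C(=O)N(c2cc(NC(=O)c4ccc(C)c(C(F)(F)F)c4)ccc2C)C3)cn1` gives 870 nM and compound 3 `Cc1ccc(Nc2ncc3c(n2)N(C2CC2)C(=O)N(c2cc(NC(=O)c4ccc(C)c(C(F)(F)F)c4)ccc2C)C3)cn1` gives 649 nM. Compound 3 holds the second highest of these three numbers, yet it lies within the scatter of both of the others, so its place among them carries no real order.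

The next compound is compound 4 `Cc1ccc(Nc2ncc3c(n2)N(c2ccccc2)C(=O)N(c2cc(NC(=O)c4ccc(C)c(C(F)(F)F)c4)ccc2C)C3)cn1`, which differs from compound 3 in one place: phenyl in place of cyclopropyl on an amide-type nitrogen in a ring. In words, this is phenyl in place of cyclopropyl on an amide-type nitrogen in a ring. Within the data shown here, only one measured step bears on this nitrogen, a 1.3-fold lower number from compound 2 to compound 3 (0.13 log units; within the scatter), with cyclopropyl in place of methyl, and it stays within the scatter. Among the measured compounds shown here, no measured compound carries phenyl at this place, so that single small step is a limited guide, and the range has to stay wide in both directions. On the evidence of that step, no change beyond the scatter is expected in this assay, and the expected step is a 1.1-fold higher number from compound 3 to compound 4 (0.03 log units; within the scatter). For compound 4 the estimate is 700 nM, with an expected range of 250 nM to 1900 nM.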

Compound 4, concentration for 50% growth inhibition: 3300 nM
Compound 4: the middle estimate sits 4.7-fold (0.67 log units) below what was measured, and the stated range ends below it.
By their numbers in this assay, from the lowest: compounds 1, 3 and 2 (each within the scatter of the next); then compound 4.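

Until now the group on this amide-type nitrogen in a ring had made no readable difference, as methyl and cyclopropyl lie within the scatter of each other. Phenyl is the first group here to move the number beyond the scatter, giving a 5.1-fold higher number from compound 3 to compound 4 (0.71 log units; beyond the scatter) and a 3.8-fold higher number from compound 2 to compound 4 (0.58 log units; beyond the scatter) in this assay, both towards weaker inhibition of growth, so this position does respond to the group it carries, and the latitude seen with the two smaller groups does not extend to phenyl. No measurement shown here accounts for this loss.

The step from cyclopropyl to phenyl changes both ring size and aromatic character, and the compounds shown cannot separate the two; cyclohexyl, a six-membered ring of carbon only that is not aromatic, would tell them apart. Among these compounds, it also remains open whether a phenyl ring carrying an amine or a carboxylic acid, or a pyridyl ring with nitrogen in the ring itself, would fare the same at this nitrogen, since phenyl is the only aromatic group seen here.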